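The source may report more compounds than this note shows. Statements on the series, on what has been measured and on what is new or still open speak of the compounds shown alone.

Readings in the series come from an assay on isolated protein for displacement of a labelled ligand from thyroid hormone receptor alpha (Homo sapiens), read by fluorescence polarization; a higher number here means a weaker inhibitor, a lower number a stronger inhibitor. Compound 1 `CCCCCCc1ccc(C(=O)CCN(C(C)C)C(C)C)cc1` gives 4100 nM in this assay. Compound 2 `C=CC(=O)[C@H]1CC[C@H](CC(C)(C)C)CC1` gives 75600 nM in this assay. For the measured compounds named here, compound 3 `C/C=C/C(=O)Nc1ccc(CCCCCC)cc1` returns only a limit in this assay, > 100000 nM; it is the single value among the three that sits at the limit of > 100000 nM in this assay, at which 1 of the 3 values shown sits, so no number is known for it. Compound 1 and compound 2 carry numbers, compound 3 does not, and its standing can be given only as the weak end of what this assay reports.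

Compound 4 `C#CC(=O)Nc1ccc(CCCCCC)cc1` has not yet been measured in this assay. It differs from compound 3 in one place: ethynyl in place of prop-1-en-1-yl on a carbonyl carbon. The amide nitrogen, the carbonyl and the shared core are kept; only the group on the carbonyl carbon changes, from a chain with a double bond outside aromatic rings to a shorter one with a triple bond. Going by the values given here, no measured pair in the set makes this same change, so no step size can be read from the data. Expected in this assay is a step that the limit leaves unreadable from compound 3 to compound 4, that is, no change beyond the scatter. Compound 4 is therefore expected to give about 150000 nM in this assay, within 50000 nM to 500000 nM, most probably again as a limit rather than a number.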

Compound 4, half-maximal inhibitory concentration in the thyroid hormone receptor alpha assay: 68900 nM
Beside the measured number, compound 4's estimate is 2.2-fold (0.34 log units) above it, within the range that was stated.
By their numbers in the thyroid hormone receptor alpha assay, from the lowest: compound 1; then compounds 4 and 2 (each within the scatter of the next). At a limit, above all of these: compound 3.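

In the thyroid hormone receptor alpha assay the change to ethynyl from prop-1-en-1-yl on a carbonyl carbon reads as an at least 1.4-fold lower number from compound 3 to compound 4 (0.16 log units; that floor lies within the scatter), which gives this position its first step, though only as a floor, and puts a number rather than a limit on the ethynyl side of the pair. In the thyroid hormone receptor alpha assay compound 3 gives > 100000 nM, which is a limit and not a number. The real size of the step stays unknown: the limit of > 100000 nM in the thyroid hormone receptor alpha assay, at which 1 of the 4 values shown sits.
In a physicochemical assay for solubility, in phosphate buffer (a higher number here means a more soluble compound, a lower number a less soluble compound), compound 3 gives 42000 nM and compound 4 gives 60000 nM. In the physicochemical assay the same change reads as a 1.4-fold higher number from compound 3 to compound 4 (0.15 log units; within the scatter), so nothing can be read in that assay beyond the scatter.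

Open in the thyroid hormone receptor alpha assay is whether the step belongs to the triple bond or to the shorter group, and an ethyl group on the same carbonyl carbon would separate the two. Also open, going by these compounds, are how a longer chain with a triple bond would read at this place, and whether the change carries over to the cores of compound 1 and compound 2, which differ from this pair in more than one place.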